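The compounds below may be only part of what the source reports. "The series", "measured", "known", "first", "only" and "open" are said of these compounds alone.

Growth inhibition in a functional assay on BXPC-3 cells (Homo sapiens) for inhibition, read by MTT assay, with a stated time of 72 h; a lower number here means a stronger inhibitor of growth, a higher number a weaker inhibitor of growth:
compound 1 `O=S(=O)(NCCCNCc1cccc2ccccc12)c1cc(C(F)(F)F)cc(C(F)(F)F)c1` gives 2700 nM
compound 2 `O=S(=O)(NCCCNCc1ccc(Cl)cc1)c1cc(C(F)(F)F)cc(C(F)(F)F)c1` gives 1600 nM
compound 3 `O=S(=O)(NCCCNCc1ccccc1)c1cc(C(F)(F)F)cc(C(F)(F)F)c1` gives 13000 nM

Compound 3 stands highest of the three, beyond the scatter from both others. Compound 4 `O=S(=O)(NCCCNCc1ccc(Cl)c(Cl)c1)c1cc(C(F)(F)F)cc(C(F)(F)F)c1` is not yet measured; its change from compound 3 is 3,4-dichlorophenyl in place of phenyl on a saturated chain carbon bound to an amine nitrogen. Among the measured compounds shown here, the one measured step that bears on this is an 8.1-fold higher number from compound 2 to compound 3 (0.91 log units; beyond the scatter), a chloro-to-hydrogen change, which read in reverse points to a lower number on entering chloro. For the measured compounds named here, no measured pair tells what a second chloro adds, so the expected step in this assay is lower, of about the size of that step, with the extra chloro left uncertain. Compound 4 is estimated at 1300 nM, range 400 nM to 4000 nM, an expected step of a 10-fold lower number from compound 3 to compound 4 (1.00 log units; beyond the scatter).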

Compound 4, concentration for 50% growth inhibition: 1400 nM
Compound 4: the middle estimate sits 1.1-fold (0.03 log units) below what was measured; the measured number falls inside the stated range.
By their numbers in this assay, from the lowest: compounds 4, 2 and 1 (each within the scatter of the next); then compound 3.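

In this assay, the 3,4-dichlorophenyl group shows a 9.3-fold lower number from compound 3 to compound 4 (0.97 log units; beyond the scatter) and so keeps the level reached with 4-chlorophenyl, while the second chloro adds no readable change, with a 1.1-fold lower number from compound 2 to compound 4 (0.06 log units; within the scatter) as the step. With a 1.9-fold lower number from compound 1 to compound 4 (0.29 log units; within the scatter) as the remaining step, compound 1, compound 2 and compound 4 form one level, and only the plain phenyl of compound 3 stands apart. No measurement here gives a reason for this level.

Open, from the compounds shown here alone, is whether 3-chlorophenyl alone reaches this level, and whether 4-methoxyphenyl or a pyridine ring holds it. Going by these compounds, a longer chain in the shared core also remains untested in these compounds.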